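From bromo to hydroxy on an aromatic carbon

A few compounds are considered here, and "the series" means these few. Any claim that something is new, unique, unknown or untested is made for them only; others in the source may bear on it.

Among the measured compounds shown here, in a functional assay on MGC-803 cells (Homo sapiens) for inhibition, read by MTT assay, with a stated time of 48 h (on this read-out lower numbers stand for stronger inhibition and higher numbers for weaker inhibition), only two compounds have numbers so far. Compound 1 (`COc1ccc(CN(C(=O)C(C)Br)c2cc(OC)c(OC)c(OC)c2)cc1O`) gives 120 nM. Compound 2 (`C/C=C/C(=O)N(Cc1ccc(OC)c(Br)c1)c1cc(OC)c(OC)c(OC)c1`) gives 6430 nM, the higher of the two numbers and so the weaker inhibition, with a gap beyond the scatter. Compound 3 (`C/C=C/C(=O)N(Cc1ccc(OC)c(O)c1)c1cc(OC)c(OC)c(OC)c1`) differs from compound 2 in one place: hydroxy in place of bromo on an aromatic carbon, ortho to a methoxy group (hydroxy in place of bromo on an aromatic carbon). For the measured compounds named here, no measured pair isolates this change, since compounds 1 and 2 differ in more than one place. Still, compound 1, which also carries hydroxy there, gives 120 nM, so a moderate move toward stronger inhibition is expected rather than none. The expected step in this assay is a 4.3-fold lower number from compound 2 to compound 3 (0.63 log units; beyond the scatter). Compound 3 is estimated at 1500 nM, with an expected range of 300 nM to 6000 nM.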

Compound 3, half-maximal inhibitory concentration: 27 nM
Compound 3: the middle estimate sits 56-fold (1.74 log units) above what was measured; the measured number lies below the stated range.
By their numbers in this assay, from the lowest: compound 3; then compound 1; then compound 2.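

In this assay, among the compounds shown here, the change from 3-bromo-4-methoxyphenyl to 3-hydroxy-4-methoxyphenyl gives a 240-fold lower number from compound 2 to compound 3 (2.38 log units; beyond the scatter) as a large step, the first reading of this change on its own. With hydroxy in that place, prop-1-en-1-yl in place of 1-bromoethyl on a carbonyl carbon gives a 4.4-fold lower number from compound 1 to compound 3 (0.65 log units; beyond the scatter) as a modest step, so at this stage the aromatic position carries the larger change of the two. Nothing available explains the size of the hydroxy step.

The compounds shown leave open whether an amine or a fluoro group on this aromatic carbon would stay close to compound 3 or fall back toward compound 2. Also open, going by these compounds, is whether the same change from bromo to hydroxy gives a step of similar size when 1-bromoethyl sits on the carbonyl carbon.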